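The source may hold more compounds than are shown below. What is called first, only, known or untested is meant among the compounds shown, and "the series" means these compounds.

Of the compounds shown here, two have so far been tested in a functional assay on A549 cells (Homo sapiens) for antiproliferative activity, read by MTT assay, with a stated time of 48 h; on this read-out higher numbers stand for weaker inhibition and lower numbers for stronger inhibition. Compound 1 `Cc1ccc(-n2nncc2CN2C(=O)C3(C(C#N)=C(N)Oc4c3c3nc5ccccc5nc3c3ccccc43)c3ccccc32)cc1Cl` is one of them. In this assay compound 1 gives > 50000 nM, which is a limit of the assay and not a number. Compound 2 `N#CC1=C(N)Oc2c(N)cc3nc4ccccc4nc3c2C12C(=O)N(Cc1cnnn1-c1cccc(C(F)(F)F)c1)c1ccccc12` is the other. In this assay, going by the values given here, compound 2 gives 5400 nM, the only number recorded. Among the compounds with values here, the one further value, that of compound 1, is a limit of the assay (the limit of > 50000 nM in this assay, at which 1 of the 2 values shown sits). Compound 3 `N#CC1=C(N)Oc2c(N)cc3nc4ccccc4nc3c2C12C(=O)N(Cc1cnnn1-c1cc(Cl)ccc1Cl)c1ccccc12` has not yet been measured. It differs from compound 2 in a single place: 2,5-dichlorophenyl in place of 3-(trifluoromethyl)phenyl on an aromatic nitrogen. Within the data shown here, no pair of measured compounds that differ in one place is available, so nothing sets a size for this kind of change. Swapping one substituted phenyl ring for another on the same aromatic nitrogen is expected to move the result little, with the step from compound 2 to compound 3 estimated to stay within the scatter no change at the digits printed from compound 2 to compound 3 (within the scatter). Compound 3 is therefore expected to give about 5400 nM, somewhere between 2000 nM and 15000 nM.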

Compound 3, half-maximal inhibitory concentration: 10900 nM
For compound 3 the middle estimate is 2.0-fold (0.31 log units) below the measured one; low and high end bracket the measured number.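

This gives the first measured size for a change at this position: in this assay, 2,5-dichlorophenyl in place of 3-(trifluoromethyl)phenyl on the aromatic nitrogen produces a 2.0-fold higher number from compound 2 to compound 3 (0.31 log units; beyond the scatter). The choice of substituted phenyl ring here therefore does affect the result, moving it towards weaker inhibition, although the step is modest and both compounds still give a measured number. No measurement shown accounts for the direction or the size of this step.

The two rings differ both in which groups they carry and in where they carry them, so this single step cannot separate those two differences. Also open, from the compounds shown here alone, is how a plain phenyl ring, or a phenyl ring bearing an amine or a carboxylic acid, would read at this position.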